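Chloroaryl Amine Variant of an Anilino Quinone Scaffold

The compounds below may be only part of what the source reports. "The series", "measured", "known", "first", "only" and "open" are said of these compounds alone.

Measured so far:
Compound 1 `O=C1C(N2CCCCC2)=CC(=O)c2c1nc1n2[C@H]2OC[C@@H](O)[C@H]2OC1` — > 4000 nM
Compound 2 `CCOc1ccc(NC2=CC(=O)c3nc4n(c3C2=O)[C@H]2OC[C@@H](O)[C@H]2OC4)cc1` — 1110 nM
Compound 3 `O=C1C(NC2CCCCC2)=CC(=O)c2c1nc1n2[C@H]2OC[C@@H](O)[C@H]2OC1` — > 8000 nM

Within the data shown here, in a functional assay on MGC-803 cells (Homo sapiens) for inhibition, read by sulforhodamine B assay (a higher number here means a weaker inhibitor, a lower number a stronger inhibitor), compound 2 gives 1110 nM, the only numerical value among the three. Compound 1 reaches only a limit, > 4000 nM. Compound 3 likewise reaches only a limit, > 8000 nM. Among the measured compounds shown here, the one step between measured compounds, a step that the two limits leave unreadable from compound 1 to compound 3, cannot be read because both ends sit at limits (the limit of > 4000 nM in this assay, at which 1 of the 3 values shown sits, and (the limit of > 8000 nM in this assay, at which 1 of the 3 values shown sits)), so no measured step bears on an aryl-ring substitution. Compound 4 `O=C1C=C(Nc2cccc(Cl)c2)C(=O)c2c1nc1n2[C@H]2OC[C@@H](O)[C@H]2OC1` differs from compound 2 by 3-chlorophenyl in place of 4-ethoxyphenyl on an amine nitrogen. For the measured compounds named here, with no comparable step available, the change is expected to stay within scatter, a 1.4-fold higher number from compound 2 to compound 4 (0.13 log units; within the scatter). Compound 4 is therefore estimated at 1500 nM, within 400 nM to 6000 nM.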

Compound 4, half-maximal inhibitory concentration: 1770 nM
The estimate for compound 4 lay 1.2-fold (0.07 log units) below the measured number; low and high end bracket the measured number.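

In this assay, among these compounds, the step of a 1.6-fold higher number from compound 2 to compound 4 (0.20 log units; within the scatter) is the first readable step at this place, on an amine nitrogen whose other neighbour is a double-bonded ring carbon. It shows that 4-ethoxyphenyl, with its one hydrogen-bond acceptor, can give way to 3-chlorophenyl without a change beyond the scatter. Nothing measured here bears on this result.

Still open, from the compounds shown here alone, is whether a phenyl ring carrying a carboxylic acid or an amine, in place of 3-chlorophenyl, would move the number beyond the scatter. Going by these compounds, a benzyl group there is equally open.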